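This account rests on a few compounds, and the source may have more. Where it says the series, first, only, none or still open, it means among the compounds named here.

In a functional assay on HCT-116 cells (Homo sapiens) for cytotoxicity, read by MTT assay, with a stated time of 72 h (on this read-out higher numbers stand for weaker inhibition and lower numbers for stronger inhibition), compound 1 `O=C1C=CCC/C1=C\C=C\c1ccccc1` gives 5400 nM, and compound 2 `CC(=C\c1ccccc1)/C=C1\CCC=CC1=O` gives 4800 nM. These two values lie within the scatter of each other. Compound 3 `O=C1C=CCC/C1=C\C(Br)=C\c1ccccc1` returns only a limit, > 10000 nM.

Compound 4 `Cc1ccc(/C=C/C=C2\CCC=CC2=O)cc1` carries methyl in place of hydrogen on an aromatic carbon, that is, methyl in place of hydrogen on an aromatic carbon, para to a large group. Going by the values given here, no measured step touches the aromatic ring. Among the compounds with values here, the nearest precedent is methyl on the chain, a 1.1-fold lower number from compound 1 to compound 2 (0.05 log units; within the scatter). The bromo step, an at least 1.8-fold higher number from compound 1 to compound 3 (0.26 log units; that floor lies within the scatter), rests on a limit and involves a different group, so it bears less. No step beyond the scatter is therefore expected, and the expected step is a 1.1-fold lower number from compound 1 to compound 4 (0.03 log units; within the scatter). Compound 4 is estimated at 5000 nM, with an expected range of 2500 nM to 9500 nM.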

Compound 4, half-maximal inhibitory concentration: 7200 nM
Compound 4: middle estimate off by 1.4-fold (0.16 log units), on the low side, and the stated range covers the measured number.
By their numbers in this assay, from the lowest: compounds 2, 1 and 4 (each within the scatter of the next). At a limit, above all of these: compound 3.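

The aromatic ring now has a step of its own: methyl in place of hydrogen on an aromatic carbon, para to a large group, gives a 1.3-fold higher number from compound 1 to compound 4 (0.12 log units; within the scatter) in this assay. At this position, methyl therefore produces no step beyond the scatter, and the same holds for methyl on the chain, with a 1.1-fold lower number from compound 1 to compound 2 (0.05 log units; within the scatter). Nothing measured here gives a reason for the size of either step. Still open, going by these compounds, is how this position responds to an amine, a carboxylic acid or a longer chain. Other places on the aromatic ring also remain open.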